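The source may hold more compounds than are shown below. What is called first, only, known or untested is meant among the compounds shown, and "the series" means these compounds.

Two compounds share one core and were tested in a functional assay on the whole organism with Rattus norvegicus as the target, at a dose of 20 mg/kg by the oral route; on this read-out lower numbers stand for less inhibition and higher numbers for more inhibition at the one dose given (going by the name of the read-out). Compound 1 `CNC(=O)/C=C1\CCc2ccc(Cl)cc21` gives 0% in this assay, and compound 2 `O=C(/C=C1\CCc2ccc(F)cc21)N1CCCC1` gives 10%, so compound 2 and compound 1 sit within the usual scatter of each other, with no real difference between them. The next compound, compound 3 `CNC(=O)/C=C1\CCc2ccc(F)cc21`, differs from compound 2 in one place: methylamino in place of pyrrolidin-1-yl on a carbonyl carbon. Within the data shown here, with only two measured values and no step between them beyond the scatter, the expected step of a number 6 percentage points lower from compound 2 to compound 3 (within the scatter) is none beyond the scatter. Compound 3 is therefore expected to give about 4% in this assay, within a range from 0% to 15%.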

Compound 3, a percentage reported as inhibition, in the whole organism at one dose (the size of the read-out at that dose, not a potency): 45%
Compound 3: the middle estimate sits 41 percentage points below what was measured, outside the stated range (above it).
By their numbers in this assay, from the lowest: compounds 1 and 2 (each within the scatter of the next); then compound 3.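

Methylamino in place of pyrrolidin-1-yl on a carbonyl carbon gives a number 35 percentage points higher from compound 2 to compound 3 (beyond the scatter) in this assay, so the group at this place clearly affects the read-out. Fluoro in place of chloro on an aromatic carbon, with methylamino kept, gives a number 45 percentage points higher from compound 1 to compound 3 (beyond the scatter), so a second place on the shared core matters as well. Nothing available explains either step.

As far as these compounds go, it remains open whether dimethylamino or ethylamino on the carbonyl carbon would give a similar number. From the compounds shown here alone, how bromo or plain hydrogen on the aromatic carbon would compare also remains open.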